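This account rests on a few compounds, and the source may have more. Where it says the series, first, only, none or still open, it means among the compounds named here.

Of the compounds shown here, three have so far been tested in an ADME assay on cells (Macrophage cell line, Homo sapiens) for cytotoxicity, read by MTT assay, with stated times of 24 h and 48 h; on this read-out lower numbers stand for stronger inhibition and higher numbers for weaker inhibition. Compound 1 `O=C(O)c1cc(O)cnc1-c1ccccc1` gives 87900 nM, compound 2 `COc1cccc(-c2cc(C(=O)[O-])c(O)c[n+]2C)c1` gives 96000 nM, and compound 3 `O=C(O)c1cnc2c(F)cc(F)cc2c1O` gives 96500 nM. These three numbers sit so close together that the gap from compound 2 to compound 3, and the gap from compound 2 to compound 1, both fall within the ordinary scatter of repeated measurements, so none of the three can be set apart from the others on this read-out.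

Compound 4 `C[n+]1cc(O)c(C(=O)[O-])cc1-c1ccccc1` shares the core of compound 2 and differs from it at a single place: hydrogen in place of methoxy on an aromatic carbon. Going by the values given here, no pair of measured compounds shows what this kind of change does here, so the only guide is that every change tried so far has left the number essentially where it was. For that reason a step in this assay from compound 2 to compound 4 is expected to be small, with no direction beyond the scatter, as a 1.0-fold lower number from compound 2 to compound 4 (0.02 log units; within the scatter). Compound 4 is therefore estimated to give 92000 nM in this assay, with a range from 46000 nM to 184000 nM.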

Compound 4, half-maximal inhibitory concentration: 91400 nM
Beside the measured number, compound 4's estimate is 1.0-fold (0.00 log units) above it, and the stated range covers the measured number.
By their numbers in this assay, from the lowest: compounds 1, 4, 2 and 3 (each within the scatter of the next).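

Going by these compounds alone, compound 2 and compound 4 form the first pair that differs in one place only, so the effect of that place can now be read directly: with hydrogen in place of methoxy on an aromatic carbon, meta to a large group, this assay shows a 1.1-fold lower number from compound 2 to compound 4 (0.02 log units; within the scatter). At this place, then, the read-out does not separate a methoxy from a bare hydrogen, and the two compounds cannot be told apart. No supporting measurement is available to explain this result.

The comparison covers only these two substituents at this one place on the ring. From the compounds shown here alone, whether an amine, a carboxylic acid or a longer chain at the same place would also stay within the scatter remains open.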